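A sulfonyl substituent exchange with no measured anchor

The source may hold more compounds than are shown below. What is called first, only, known or untested is meant among the compounds shown, and "the series" means these compounds.

In an ADME assay on BJ cells (Homo sapiens) for antiproliferative activity, with a stated time of 72 h (a lower number here means that less compound is needed, a higher number that more compound is needed for the effect), the three measured compounds give the following:
compound 1 `COC(=O)c1cc(=O)c2c(OC)cc(OC)cc2[nH]1`: > 34400 nM
compound 2 `COC(=O)c1cc(=O)c2cc(N)ccc2[nH]1`: > 67200 nM
compound 3 `COc1ccc(-c2cc(=O)c3c(OC)cc(OC)cc3n2S(=O)(=O)c2ccc(F)cc2)cc1`: > 65500 nM

Every one of these values is a limit of the assay and not a number. Compound 1 sits at the limit of > 34400 nM in this assay, at which 1 of the 3 values shown sits. Compound 2 sits at the limit of > 67200 nM in this assay, at which 1 of the 3 values shown sits. Compound 3 sits at the limit of > 65500 nM in this assay, at which 1 of the 3 values shown sits. Compound 3 therefore stands nowhere in particular on the numbers shown: its value in this assay is a limit, and the two other values are limits as well, so no ordering among the three compounds can be read from them.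

Compound 4 `COc1ccc(-c2cc(=O)c3c(OC)cc(OC)cc3n2S(=O)(=O)Cc2ccccc2)cc1` differs from compound 3 in one place: benzyl in place of 4-fluorophenyl on a sulfonyl sulfur. For the measured compounds named here, no step between measured compounds is available to set the size of this change in this assay, and compound 3 itself offers only a limit. The expectation is a step of no size beyond the scatter, written as a step that the limit leaves unreadable from compound 3 to compound 4, with the reading most likely ending again as a limit, because compound 3 gives > 65500 nM. Compound 4 is thus estimated at 70000 nM, within a range from 20000 nM to 250000 nM.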

Compound 4, half-maximal effective concentration: > 34400 nM
Compound 4: a limit, no number; the forecaster's own chance of this, stated with the estimate: 85%; the middle value does not contradict the limit.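

In this assay compound 4 gives > 34400 nM as a limit of the assay and not a number. Compound 3 gives > 65500 nM as a limit too. No step can be read between compound 3 and compound 4. The compounds shown leave open whether benzyl in place of 4-fluorophenyl on a sulfonyl sulfur changes the read-out at all.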